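Swapping Fluoro for Nitro: What to Expect for Compound 4

A few compounds are considered here, and "the series" means these few. Any claim that something is new, unique, unknown or untested is made for them only; others in the source may bear on it.

Three compounds have so far been measured in a functional assay on T98G cells (Homo sapiens) for cytotoxicity, read by MTT assay, with a stated time of 48 h; on this read-out lower numbers stand for stronger inhibition and higher numbers for weaker inhibition:

Compound 1, `C/C(=N/NC(=S)Nc1ccccc1F)c1ccccn1`, gives 3.1 nM.
Compound 2, `C/C(=N/NC(=S)Nc1ccccc1[N+](=O)[O-])c1ccccn1`, gives 6.61 nM.
Compound 3, `CC(=NNC(=S)Nc1ccc(F)cc1)c1ccccn1`, gives 17 nM.

Compound 3 thus shows the highest of the three numbers, and its distance to both others lies beyond the scatter of this assay. Compound 2 differs from compound 1 by nitro in place of fluoro on an aromatic carbon, and that change produced a 2.1-fold higher number from compound 1 to compound 2 (0.33 log units; beyond the scatter). How the core of compound 3 differs from the core of compound 1 is not broken down here.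

Compound 4, `CC(=NNC(=S)Nc1ccc([N+](=O)[O-])cc1)c1ccccn1`, has not been measured yet. It differs from compound 3 by nitro in place of fluoro on an aromatic carbon. Among the measured compounds shown here, this is the same kind of change as the one from compound 1 to compound 2, though not the same: in compound 2 the entering group sits ortho to a large group, whereas in compound 4 it sits para to a large group. Because a 2.1-fold higher number from compound 1 to compound 2 (0.33 log units; beyond the scatter) was modest, the expected step is a 2.1-fold higher number from compound 3 to compound 4 (0.33 log units; beyond the scatter). The estimate for compound 4 in this assay is 36 nM, expected to fall between 12 nM and 110 nM.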

Compound 4, half-maximal inhibitory concentration: 140 nM
The estimate for compound 4 lay 3.9-fold (0.59 log units) below the measured number; measured number above the stated range.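

In this assay, the swap of fluoro for nitro gave an 8.2-fold higher number from compound 3 to compound 4 (0.92 log units; beyond the scatter), so the number rose on both cores, as it had with the earlier pair. The size of the step did not carry over, however: the same change on two cores in this assay, a 2.1-fold higher number (0.33 log units; beyond the scatter) from compound 1 to compound 2 and an 8.2-fold higher number (0.92 log units; beyond the scatter) from compound 3 to compound 4, 3.9-fold (0.59 log units) apart, beyond the scatter of two such steps

This shows that, on these two cores, the change moved the number in the same direction but by clearly different amounts, so one step could not be used to predict the size of the other; it does not show why they differ, or whether the larger step belongs to the nitro group sitting para to a large group or to something else about the core of compound 3.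

The compounds shown carry only fluoro or nitro on this aromatic ring, so it remains open how other groups, such as an amine or a carboxylic acid, would behave in the same place. On these data alone, it also remains open whether the same swap on a further core would give a step closer to the smaller or the larger one.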